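Swapping 2,3-dichlorophenyl for 3,4-dichlorophenyl on a shared core

This account rests on a few compounds, and the source may have more. Where it says the series, first, only, none or still open, it means among the compounds named here.

Compound 1 `N#Cc1ccc(/C=N/NC(=O)Nc2ccc(Oc3ccnc4[nH]ccc34)c(F)c2)cc1` gives 850 nM
Compound 2 `O=C(N/N=C/c1cccc(Cl)c1Cl)Nc1ccc(Oc2ccnc3[nH]ccc23)c(F)c1` gives "not active" (no number reported)

In a functional assay on HepG2 cells (Homo sapiens) for antiproliferative activity, read by MTT assay, with a stated time of 72 h (a lower number here means a stronger inhibitor, a higher number a weaker inhibitor), compound 2 is recorded as "not active" (no number reported) with no number, so it has no exact place on the scale. Compound 3 `O=C(N/N=C/c1ccc(Cl)c(Cl)c1)Nc1ccc(Oc2ccnc3[nH]ccc23)c(F)c1` keeps the shared core and rearranges one group: 3,4-dichlorophenyl in place of 2,3-dichlorophenyl on a carbon with a double bond to nitrogen. For the measured compounds named here, no measured pair shows what such a swap does, so any expectation is loose. A step towards stronger inhibition is expected, landing in the region of compound 1 at 850 nM in this assay but probably somewhat weaker. The estimate for compound 3 is 2000 nM as the expected value, with an expected range from 400 nM to 10000 nM in this estimate.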

Compound 3, half-maximal inhibitory concentration: 3700 nM
Compound 3: the middle estimate sits 1.9-fold (0.27 log units) below what was measured; low and high end bracket the measured number.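

In this assay, compound 3 shows that a dichlorophenyl group at this place can give a measurable number, whereas compound 2, with 2,3-dichlorophenyl, is recorded as not active. The size of that swap cannot be read, as compound 2 has no number. Replacing 4-cyanophenyl with 3,4-dichlorophenyl gives a 4.4-fold higher number from compound 1 to compound 3 (0.64 log units; beyond the scatter), so compound 3 is the weaker inhibitor of the two.

Nothing available explains these differences. Also open, from the compounds shown here alone, is how a single chlorine, a methoxy group or an amine would fare at this place.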